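A few compounds are considered here, and "the series" means these few. Any claim that something is new, unique, unknown or untested is made for them only; others in the source may bear on it.

Compound 2, `CC(C)COC(=O)C(O)Cn1cnc2c(N)ncnc21`, and compound 1, `CCCOC(=O)C(O)Cn1cnc2c(N)ncnc21`, share the same core and differ only in the ester chain. In a functional assay on Vero cells (Chlorocebus sabaeus) for cytotoxicity (a higher number here means that more compound is tolerated, a lower number that less compound is tolerated), compound 1 reaches > 400 ug/mL, which is a limit of the measurement and not a number. In this assay compound 2 likewise reaches > 400 ug/mL, again a limit rather than a number. The step that the two limits leave unreadable from compound 1 to compound 2 therefore has no readable size, since both of its ends rest on (the limit of > 400 ug/mL in this assay, at which 2 of the 2 values shown sit). Compound 2 thus stands at the upper edge of what the measurement can report, side by side with compound 1.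

Compound 3, `CCOC(=O)C(O)Cn1cnc2c(N)ncnc21`, carries methyl in place of isopropyl on a saturated chain carbon bound to an oxygen next to a carbonyl group. Among the compounds with values here, the only measured step in this assay, a step that the two limits leave unreadable from compound 1 to compound 2, also altered the ester chain without moving either compound off the limit, so it offers no size to carry over; it shows only that the two chains measured so far stayed at the limit. The step that the limit leaves unreadable from compound 2 to compound 3 is therefore expected to be none beyond the scatter. Compound 3 is expected to be tolerated up to 500 ug/mL, with a range from 200 ug/mL to 1200 ug/mL, and most likely reported once more as a limit.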

Compound 3, minimum cytotoxic concentration: > 400 ug/mL
Compound 3: only a limit was reported; the forecaster's own chance of this, stated with the estimate: 80%; the middle value does not contradict the limit.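

No step among compound 1, compound 2 and compound 3 can be read, since each result is a limit and not a number, so the changes in the ester chain have no size: the limit of > 400 ug/mL in this assay, at which 3 of the 3 values shown sit.

The compounds shown leave open where each one's true tolerated amount in this assay lies, and whether these ester chains differ at all.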